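Extending the butyl amide chain: compound 3 to compound 4

A few compounds are considered here, and "the series" means these few. Any claim that something is new, unique, unknown or untested is made for them only; others in the source may bear on it.

Measured in an ADME assay on DU-145 cells (Homo sapiens) for cytotoxicity, read by MTT assay, with a stated time of 72 h; a lower number here means a stronger inhibitor of growth, a higher number a weaker inhibitor of growth:
- compound 1 `O=C(O)C1C(C(=O)NCC2Cc3ccsc3CO2)[C@H]2CC[C@@H]1O2`: 10000 nM
- compound 2 `CCOC(=O)c1cn[nH]c1NC(=O)C1C(C(=O)O)[C@@H]2CC[C@H]1O2`: 10000 nM
- compound 3 `CCCCNC(=O)C1C(C(=O)O)[C@@H]2CC[C@H]1O2`: 10000 nM

Compound 1 and compound 2 stand level with compound 3 at 10000 nM, and no gap beyond the scatter separates the three. The groups on their amide nitrogens differ, yet the readings do not, so the set offers no trend to extend. Within the data shown here, no measured pair isolates a single structural change.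

The next compound is compound 4 `CCCCCCCCNC(=O)C1C(C(=O)O)[C@@H]2CC[C@H]1O2`, which differs from compound 3 as follows: butyl in place of hydrogen on a saturated chain carbon, four bonds along the chain from an amide-type nitrogen. Among the measured compounds shown here, no measured step speaks directly to this change, so the expectation is uncertain. A modest move towards stronger growth inhibition in this assay is expected, possibly not beyond the scatter, and no change would be equally unsurprising. The expected size of the change is a 1.4-fold lower number from compound 3 to compound 4 (0.15 log units; within the scatter). Compound 4 is estimated at 7000 nM, with an expected range of 2000 nM to 20000 nM.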

Compound 4, concentration for 50% growth inhibition: 10000 nM
For compound 4 the middle estimate is 1.4-fold (0.15 log units) below the measured one, and the stated range covers the measured number.
By their numbers in this assay, from the lowest: compounds 1, 2, 3 and 4 (each within the scatter of the next).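

In this assay the series now has its first pair that differs in one place: butyl in place of hydrogen on a saturated chain carbon, four bonds along the chain from an amide-type nitrogen, gives no change at the digits printed from compound 3 to compound 4 (within the scatter) in this growth read-out. The earlier compounds shown here differ in their amide groups as a whole and could not show this; the step shows that adding butyl at this place does not separate the two compounds. Nothing in the data explains this reading.

Going by these compounds, whether a longer chain at this place, or an amine or a phenyl group in place of the butyl, would move the number in this assay stays open. Also open, on these data alone, is whether a methyl ester in place of the carboxylic acid on the shared core would do so.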